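The source may hold more compounds than are shown below. What is called first, only, known or untested is meant among the compounds shown, and "the series" means these compounds.

Within the data shown here, in an in vitro assay on HEK385-7 cells for displacement of a labelled ligand from prostaglandin D2 receptor 2 (Homo sapiens) (on this read-out higher numbers stand for weaker inhibition and lower numbers for stronger inhibition), compound 2 `NS(=O)(=O)c1ccc(-c2nc(C(c3ccc(F)cc3)c3ccc(F)cc3)sc2CC(=O)O)cc1` gives 1500 nM, the higher of the two numbers measured so far. Compound 1 `N#Cc1ccc(-c2nc(C(c3ccc(F)cc3)c3ccc(F)cc3)sc2CC(=O)O)cc1` gives 150 nM in this assay. Among the measured compounds shown here, the only measured step, a 10-fold higher number from compound 1 to compound 2 (1.00 log units; beyond the scatter), changes the group on an aromatic carbon of the shared core, and compound 3 `CS(=O)(=O)Nc1cccc(-c2nc(C(c3ccc(F)cc3)c3ccc(F)cc3)sc2CC(=O)O)c1` changes that group again: it carries 3-(methanesulfonamido)phenyl in place of 4-sulfamoylphenyl on an aromatic carbon. That single step shows the number can shift when this group is altered, but it does not cover the present change, so no direction can be read from it. Compound 3 is therefore expected to give 1000 nM, between 200 nM and 5000 nM, an estimated step of a 1.5-fold lower number from compound 2 to compound 3 (0.18 log units; within the scatter) that would stay within the scatter.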

Compound 3, half-maximal inhibitory concentration: 40 nM
The estimate for compound 3 lay 25-fold (1.40 log units) above the measured number, and the stated range ends above it.
By their numbers in this assay, from the lowest: compound 3; then compound 1; then compound 2.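

Placing 3-(methanesulfonamido)phenyl on this ring carbon instead of 4-sulfamoylphenyl gives a 38-fold lower number from compound 2 to compound 3 (1.57 log units; beyond the scatter), a far larger shift than the earlier step showed. The new group also improves on 4-cyanophenyl, with a 3.8-fold lower number from compound 1 to compound 3 (0.57 log units; beyond the scatter), so compound 3 has the lowest number of the three. Nothing measured here explains these shifts. The change alters both the sulfur-containing group and its place on the phenyl ring, and the compounds shown cannot separate these two effects. A 4-(methanesulfonamido)phenyl group would test the place alone, while an ethanesulfonamido group would test a longer chain.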